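The compounds below may be only part of what the source reports. "The series", "measured", "known", "first", "only" and "open" are said of these compounds alone.

In a functional assay on SK-BR-3 cells (Homo sapiens) for antiproliferative activity, read by MTT assay, with a stated time of 72 h (on this read-out higher numbers stand for weaker inhibition and lower numbers for stronger inhibition), compound 1 `Cc1cc(N(C)C)nc2ccc(NC(=O)c3ccc(Cl)c(Cl)c3)cc12` gives > 50000 nM, which is a limit of the assay and not a number. Among the measured compounds shown here, compound 2 `Cc1cc(NCCN2CCN(C)CC2)nc2ccc(NC(=O)c3ccc(Cl)c(Cl)c3)cc12` gives 2690 nM, the only true number so far. Compound 3 `CCN(CC)CCNc1cc(C)c2cc(NC(=O)c3ccc(Cl)c(Cl)c3)ccc2n1` differs from it at the chain end: diethylamino in place of 4-methylpiperazin-1-yl on a saturated chain carbon, two bonds along the chain from a nitrogen on an aromatic ring. For the measured compounds named here, only one measured step bears on this, the large at least 18-fold lower number from compound 1 to compound 2 (1.26 log units; beyond the scatter), seen with (2-(4-methylpiperazin-1-yl)ethyl)amino in place of dimethylamino on an aromatic carbon. Compound 3 carries (2-(diethylamino)ethyl)amino there, not dimethylamino, so no collapse towards that limit is expected. The expected step of a 1.2-fold lower number from compound 2 to compound 3 (0.09 log units; within the scatter) is estimated to stay within the scatter. For compound 3 the estimated value is 2200 nM, with a range of 800 nM to 6500 nM.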

Compound 3, half-maximal inhibitory concentration in the SK-BR-3 assay: 3710 nM
The estimate for compound 3 lay 1.7-fold (0.23 log units) below the measured number; low and high end bracket the measured number.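

In the SK-BR-3 assay, replacing 4-methylpiperazin-1-yl with diethylamino gives a 1.4-fold higher number from compound 2 to compound 3 (0.14 log units; within the scatter), so the ring at the chain end is not needed to keep this activity. In a physicochemical assay for solubility (a higher number here means a more soluble compound, a lower number a less soluble compound), compound 2 gives 106 ug/mL and compound 3 gives 95.2 ug/mL. In the physicochemical assay the same change gives a 1.1-fold lower number from compound 2 to compound 3 (0.05 log units; within the scatter). The advantage over dimethylamino on the aromatic carbon therefore holds with a second chain end, as the SK-BR-3 assay shows an at least 13-fold lower number from compound 1 to compound 3 (1.12 log units; beyond the scatter). The value for compound 1 in that step is a limit of the assay, not a number. Still open, from the compounds shown here alone, is whether a chain ending in a hydroxyl group instead of an amine, or a longer chain, would keep this activity.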